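A few compounds are considered here, and "the series" means these few. Any claim that something is new, unique, unknown or untested is made for them only; others in the source may bear on it.

Two compounds have been measured so far in a physicochemical assay for solubility, in phosphate buffer, with a stated time of 2 h, at pH 6.5; on this read-out lower numbers stand for lower solubility and higher numbers for higher solubility:

- compound 1 `Cc1ccncc1C(=O)N1CC(Oc2cncc(N3C(=O)c4ccc(Cl)cc4C3(C)C)c2)C1` gives 290 ug/mL
- compound 2 `CCS(=O)(=O)N1CCC(c2cncc(N3C(=O)c4ccc(Cl)cc4C3(C)C)c2)CC1` gives 39 ug/mL

Compound 1 has the higher number of the two, and its gap to compound 2 lies beyond the usual scatter of repeated measurements. These two compounds differ in more than one place, so their gap cannot be tied to any single change.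

The next compound to be measured is compound 3 `CC1(C)c2cc(Cl)ccc2C(=O)N1c1cncc(OC2CN(C(=O)c3ncccc3Cl)C2)c1`. It places 3-chloropyridin-2-yl in place of 4-methylpyridin-3-yl on a carbonyl carbon. For the measured compounds named here, no measured pair shows this swap, so any expectation here is tentative. Compound 1 (290 ug/mL) sits at the top of the small measured range, which leaves more room to fall towards compound 2 (39 ug/mL) than evidence for a rise. The expected result is a modest drop, a 2.4-fold lower number from compound 1 to compound 3 (0.38 log units; beyond the scatter), although a result close to the starting value would not be surprising. In this assay compound 3 is estimated at 120 ug/mL, with an expected range from 40 ug/mL to 320 ug/mL.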

Compound 3, solubility: 20 ug/mL
Estimate against measurement, compound 3: 6.0-fold (0.78 log units) above; measured number below the stated range.
By their numbers in this assay, from the lowest: compounds 3 and 2 (each within the scatter of the next); then compound 1.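

In this assay, placing 3-chloropyridin-2-yl in place of 4-methylpyridin-3-yl on a carbonyl carbon gives a large step, a 15-fold lower number from compound 1 to compound 3 (1.16 log units; beyond the scatter), and this is the first change at a single place among the compounds shown. The result shows that this position, on a carbonyl carbon whose other neighbour is an amide-type nitrogen in a ring, can move the read-out strongly, even though the two groups match in heavy atoms, in being one six-membered aromatic ring with 1 hetero atom, in hydrogen-bond donors and acceptors, and in having no net charge. Nothing measured here explains why the number falls so far.

This single step cannot separate the role of the chlorine from that of the lost methyl or of the different attachment of the pyridine ring, and a pyridine ring carrying methyl in place of the chlorine on the same carbonyl carbon would begin to pull these apart. From the compounds shown here alone, it also remains open how a group of another kind at this position, such as a morpholine or a carboxylic acid, would read in this assay.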